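The compounds below may be only part of what the source reports. "The series", "measured", "known", "first", "only" and "open" are said of these compounds alone.

Measured in an ADME assay on J774.1 cells (Mus musculus) for cytotoxicity, read by resazurin assay, with a stated time of 48 h; on this read-out higher numbers stand for weaker inhibition and lower numbers for stronger inhibition:
- compound 1 `CCCn1cc(C(=O)NCc2ccccc2)c(=O)c2cc(F)c(N3CCC(C(N)=O)CC3)cc21`: 43700 nM
- compound 2 `CCn1cc(C(=O)NCc2ccc(OC)cc2)c(=O)c2ccc(C(F)(F)F)cc21`: > 100000 nM (a limit, not a number)
- compound 3 `CCCCn1cc(C(=O)NCc2ccc([N+](=O)[O-])cc2)c(=O)c2cc(F)c(N3CCC(C(N)=O)CC3)cc21`: > 100000 nM (a limit, not a number)

Compound 3 has no numerical value in this assay, only the limit > 100000 nM. It shares that position with one other compound, and the set as a whole is described by the limit of > 100000 nM in this assay, at which 2 of the 3 values shown sit. Among the compounds with values here, compound 1 provides the only actual number, at 43700 nM.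

The next compound is compound 4 `CCCCn1cc(C(=O)NCc2ccc(O)cc2)c(=O)c2cc(F)c(N3CCC(C(N)=O)CC3)cc21`, which has hydroxy in place of nitro on an aromatic carbon, para to a large group, so that 4-nitrobenzyl becomes 4-hydroxybenzyl: hydroxy in place of nitro on an aromatic carbon. Within the data shown here, no measured pair in the set differs in just one place, so there is no direct comparison for the size of this step. The estimate is anchored on compound 1 at 43700 nM and compound 3 at > 100000 nM. A modest shift towards stronger inhibition is expected at most, and a result beyond the scatter would be a surprise. The expected change is an at least 1.1-fold lower number from compound 3 to compound 4 (0.07 log units; that floor lies within the scatter). A report of the limit alone remains quite likely. For compound 4 the estimated value is 85000 nM, with an expected range of 40000 nM to 180000 nM.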

Compound 4, half-maximal inhibitory concentration: 41600 nM
For compound 4 the middle estimate is 2.0-fold (0.31 log units) above the measured one; low and high end bracket the measured number.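

In this assay, within the data shown here, hydroxy in place of nitro on an aromatic carbon, para to a large group, gives an at least 2.4-fold lower number from compound 3 to compound 4 (0.38 log units; beyond the scatter), the first step that can be read at one position. Among these compounds, with the butyl chain and the rest of the core unchanged, this single exchange on the benzyl group carries the series from a limit to a measured number, something the earlier compounds could not show, since no two of them differ in only one place. Compound 3 stands at a limit and not a number, which makes the step a minimum and leaves its full size unknown: the limit of > 100000 nM in this assay, at which 2 of the 4 values shown sit.

The compounds shown do not tell which difference between nitro and hydroxy accounts for the step, nor whether it would be of similar size with the propyl chain of compound 1 in place of butyl. As far as these compounds go, how an amine or a carboxylic acid at the same position of the 4-substituted benzyl group would read, and whether either would stay at the limit or fall to a measured number, also remains open.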